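This account rests on a few compounds, and the source may have more. Where it says the series, first, only, none or still open, it means among the compounds named here.

Measured compounds:
- compound 1 `NCCNc1cc(N2CCN(c3ccccc3)CC2)nc2ccccc12`: in an ADME assay on HEp-2 cells (Homo sapiens) for cytotoxicity, read by CCK-8 assay, with a stated time of 6 days (on this read-out higher numbers stand for lower toxicity in this test and lower numbers for higher toxicity in this test), compound 1 gives 20800 nM
- compound 2 `CCC(=O)N1CCN(c2cc(NCCN)c3ccccc3n2)CC1`: in this assay compound 2 gives only a limit, > 100000 nM

For the measured compounds named here, compound 1 holds the only actual number in this assay; the other value is a limit. Going by the values given here, the one measured step, an at least 4.8-fold higher number from compound 1 to compound 2 (0.68 log units; beyond the scatter), runs toward the limit of > 100000 nM in this assay, at which 1 of the 2 values shown sits, and concerns the group on the ring amine nitrogen, not the aromatic ring itself.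

Compound 3 `NCCNc1cc(N2CCN(c3ccc(Cl)cc3)CC2)nc2ccccc12` differs from compound 1 by chloro in place of hydrogen on an aromatic carbon. Among the compounds with values here, no measured step touches the aromatic ring of this series, so the propanoyl step gives no direct guide to a small substitution there. With nothing to point either way, the expected step from compound 1 to compound 3 is small: a 1.4-fold lower number from compound 1 to compound 3 (0.14 log units; within the scatter). Compound 3 is therefore estimated at 15000 nM in this assay, within a range of 5000 nM to 50000 nM.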

Compound 3, half-maximal cytotoxic concentration: 6600 nM
Compound 3: the middle estimate sits 2.3-fold (0.36 log units) above what was measured; the measured number falls inside the stated range.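

Phenyl to 4-chlorophenyl is the only change on the aromatic ring read so far in this assay, and it gives a 3.2-fold lower number from compound 1 to compound 3 (0.50 log units; beyond the scatter), so this place, para to a large group, is not neutral for toxicity in this test. The change on the ring amine nitrogen remains the larger one, with an at least 15-fold lower number from compound 2 to compound 3 (1.18 log units; beyond the scatter). That step is only a bound, and the value of compound 2 is a limit: the limit of > 100000 nM in this assay, at which 1 of the 3 values shown sits.

Still open, on these data alone, is whether fluoro, methoxy or a carboxylic acid at this place would move the number as chloro does, or whether the shift is particular to chloro. Also open, as far as these compounds go, is whether a benzoyl group on the ring amine nitrogen would read nearer to compound 1 or to compound 2.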